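This account rests on a few compounds, and the source may have more. Where it says the series, first, only, none or still open, it means among the compounds named here.

Notes on the series in a functional assay on HeLa cells (Homo sapiens) for inhibition, read by CCK-8 assay, with a stated time of 48 h; a lower number here means a stronger inhibitor, a higher number a weaker inhibitor.

Compound 2 `O=[N+]([O-])c1ccc(Oc2ccccc2-c2ccc(S(=O)(=O)NCCNC(=S)Nc3cccc(Cl)c3)s2)cc1` carries chloro on an aromatic carbon, and in this assay compound 2 gives 4600 nM. Compound 1 `COc1cccc(NC(=S)NCCNS(=O)(=O)c2ccc(-c3ccccc3Oc3ccc([N+](=O)[O-])cc3)s2)c1` has methoxy in place of chloro on an aromatic carbon. In this assay compound 1 gives > 50000 nM, which is a limit and not a number, the one described as the limit of > 50000 nM in this assay, at which 1 of the 3 values shown sits. The step of an at least 10-fold higher number from compound 2 to compound 1 (1.03 log units; beyond the scatter) is thus bounded only on one side.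

Compound 3 `O=C(NCCNS(=O)(=O)c1ccc(-c2ccccc2Oc2ccc([N+](=O)[O-])c([N+](=O)[O-])c2)s1)Nc1ccc(Cl)cc1` differs from compound 2 in more than one place, and the difference between the two cores is not broken down here. In this assay compound 3 gives > 20000 nM, which is a limit and not a number, the one described as the limit of > 20000 nM in this assay, at which 1 of the 3 values shown sits.

Compound 4 `COc1ccc(NC(=O)NCCNS(=O)(=O)c2ccc(-c3ccccc3Oc3ccc([N+](=O)[O-])c([N+](=O)[O-])c3)s2)cc1`, still to be measured, differs from compound 3 by methoxy in place of chloro on an aromatic carbon. This is the same kind of change as that from compound 2 to compound 1, but the surroundings differ: there the group sits meta to a large group, here para to a large group. Going by the values given here, the expected step that the limit leaves unreadable from compound 3 to compound 4 rests on the step of an at least 10-fold higher number from compound 2 to compound 1 (1.03 log units; beyond the scatter), where the single measured example of this change moved the number beyond the scatter toward weaker inhibition. Compound 3 already sits at a limit, so compound 4 is expected to remain at or beyond a limit in this assay. The estimate for compound 4 in this assay is 60000 nM, expected to fall between 20000 nM and 300000 nM, most likely reported as a limit only.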

Compound 4, half-maximal inhibitory concentration: > 20000 nM
Compound 4: no number, only a limit; the forecaster's own chance of this, stated with the estimate: 85%; the middle value is on the limit's open side.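

Compound 3 and compound 4 each stand at a limit in this assay and not at a number, so no step between them can be read: the limit of > 20000 nM in this assay, at which 2 of the 4 values shown sit.

The compounds shown leave open whether 4-chlorophenyl to 4-methoxyphenyl moves the number in this assay at all in this setting, and whether any such move would compare with an at least 10-fold higher number from compound 2 to compound 1 (1.03 log units; beyond the scatter).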